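The compounds below may be only part of what the source reports. "The series", "measured", "known", "first", "only" and "open" are said of these compounds alone.

Compound 1 `COc1ccc2nc(C)cc(NC(=O)C(=O)Nc3cc(C)cc(C)c3)c2c1`: in a toxicity assay on HepG2 cells (Homo sapiens) for inhibition, read by CellTiter-Glo, with a stated time of 48 h (a lower number here means a stronger inhibitor, a higher number a weaker inhibitor), compound 1 gives > 100000 nM, a limit of the assay rather than a number.
Compound 2 `COc1ccc2nc(C)cc(OCC(=O)Nc3ccccc3)c2c1`: in this assay compound 2 gives 39800 nM.
Compound 3 `COc1ccc2nc(C)cc(OCC(=O)Nc3cccc(C)c3)c2c1`: in this assay compound 3 gives 39800 nM.

Compound 3 stands level with compound 2; the step from compound 2 to compound 3 no change at the digits printed from compound 2 to compound 3 (within the scatter) is within the scatter. For the measured compounds named here, the only other value shown, that of compound 1, is a limit (the limit of > 100000 nM in this assay, at which 1 of the 3 values shown sits), so it gives no number to compare against.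

The next compound is compound 4 `COc1ccc2nc(C)cc(OCC(=O)Nc3c(C)cccc3C)c2c1`. It differs from compound 3 by 2,6-dimethylphenyl in place of 3-methylphenyl on an amide-type nitrogen. Going by the values given here, of the measured steps, only the one from compound 2 to compound 3 bears on this change, since it also added a methyl group to the phenyl ring on the amide-type nitrogen, and it showed no change no change at the digits printed from compound 2 to compound 3 (within the scatter). Adding a second methyl to the same ring is therefore expected to leave the value of compound 4 in this assay where compound 3 stands, with no step beyond the scatter. For compound 4 the estimate is 40000 nM, expected to lie between 15000 nM and 100000 nM. The expected step from compound 3 to compound 4 is thus a 1.0-fold higher number from compound 3 to compound 4 (0.00 log units; within the scatter), a step within the scatter.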

Compound 4, half-maximal inhibitory concentration: > 100000 nM
Compound 4: no number, only a limit; the forecaster's own chance of this, stated with the estimate: 35%; middle value at least 2.5-fold (0.39 log units) away from the limit.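

Where the step from phenyl to 3-methylphenyl left this assay unmoved, the group on the amide-type nitrogen now proves able to shift the read-out: 2,6-dimethylphenyl in place of 3-methylphenyl gives an at least 2.5-fold higher number from compound 3 to compound 4 (0.40 log units; beyond the scatter), and in place of phenyl it gives an at least 2.5-fold higher number from compound 2 to compound 4 (0.40 log units; beyond the scatter). A methyl group on this ring is therefore not neutral in every arrangement, and the 2,6-dimethylphenyl compound reads as a weaker inhibitor than either of the two compounds that differ from it at this place. Compound 4 carries a limit of the assay and not a number, so these steps mark only a lower bound on the change and not its full size: the limit of > 100000 nM in this assay, at which 2 of the 4 values shown sit.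

As far as these compounds go, what stays open is whether the number of methyl groups or their place on the ring carries the step, as 2,6-dimethylphenyl alters both at once. Also open, from the compounds shown here alone, is how a substituent of another kind on this ring, such as a methoxy group, a chlorine or an amine, would read in this assay.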